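This account rests on a few compounds, and the source may have more. Where it says the series, first, only, none or still open, it means among the compounds named here.

Measured in a functional assay on HT-29 cells (Homo sapiens) for antiproliferative activity, read by sulforhodamine B assay; a higher number here means a weaker inhibitor, a lower number a stronger inhibitor:
- compound 1 `c1ccc(/C(=N/Nc2nc3ccccc3o2)C2CC2)nc1`: 20600 nM
- compound 2 `C/C(=N\Nc1nc2ccccc2o1)c1ccccn1`: 132 nM
- compound 3 `CCC/C(=N\Nc1nc2ccccc2o1)c1ccccn1`: 851 nM

Of the three, compound 2 stands lowest at 132 nM, and its steps to both others lie beyond the scatter. The next compound, compound 4 `C/C(=N\Nc1nc2ccccc2o1)c1cccnc1`, has the same atoms as compound 2, joined differently: pyridin-3-yl in place of pyridin-2-yl on a carbon with a double bond to nitrogen. In short, pyridin-3-yl stands in place of pyridin-2-yl on a carbon with a double bond to nitrogen.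

Going by the values given here, no measured step changes this ring, so the evidence is indirect. The three measured steps all alter the other group on that carbon. One is modest, a 6.4-fold higher number from compound 2 to compound 3 (0.81 log units; beyond the scatter), and two are large, a 160-fold lower number from compound 1 to compound 2 (2.19 log units; beyond the scatter) and a 24-fold lower number from compound 1 to compound 3 (1.38 log units; beyond the scatter). They show that this assay can respond strongly to changes at this carbon, but they cannot say how it will respond to this exchange.

Since compound 2 already holds the lowest number at 132 nM, a higher number is the more likely outcome, by a large step rather than a modest one. The estimate amounts to an expected 23-fold higher number from compound 2 to compound 4 (1.36 log units; beyond the scatter). For compound 4 the estimated value is 3000 nM, with an expected range from 500 nM to 20000 nM.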

Compound 4, half-maximal inhibitory concentration: > 100000 nM
Compound 4: a limit, no number (the forecaster's own chance of this, stated with the estimate: 10%); at least 33-fold (1.52 log units) between middle value and limit.
By their numbers in this assay, from the lowest: compound 2; then compound 3; then compound 1. At a limit, above all of these: compound 4.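

Compound 4 reads in this assay as a limit and not a number: the limit of > 100000 nM in this assay, at which 1 of the 4 values shown sits. Exchanging pyridin-2-yl for pyridin-3-yl on a carbon with a double bond to nitrogen gives an at least 750-fold higher number from compound 2 to compound 4 (2.87 log units; beyond the scatter), larger even than the largest earlier step, a 160-fold lower number from compound 1 to compound 2 (2.19 log units; beyond the scatter). The earlier compounds shown here showed only that this assay responds to the other group on this carbon, whereas this pair shows that it also responds strongly to the aromatic ring group, even though pyridin-2-yl and pyridin-3-yl match in heavy atoms, hydrogen-bond donors, hydrogen-bond acceptors and charge.

The compounds shown leave open whether pyridin-4-yl or a plain phenyl on this carbon would read like pyridin-2-yl or like pyridin-3-yl, and so whether pyridin-2-yl is unusual among such rings or pyridin-3-yl is. Going by these compounds alone, they also leave open whether pyridin-3-yl would read the same way with propyl or cyclopropyl as the other group on this carbon, since the only comparison of the two rings has methyl there.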